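This account rests on a few compounds, and the source may have more. Where it says the series, first, only, none or still open, it means among the compounds named here.

Measured so far in a functional assay on BCG823 cells (Homo sapiens) for inhibition, read by MTT assay, with a stated time of 72 h; on this read-out higher numbers stand for weaker inhibition and lower numbers for stronger inhibition:
- compound 1 `CN(C(=O)NC(=O)c1ccc(F)c(F)c1)c1nc(C(F)(F)F)c(C(=O)N/N=C/c2ccc(C(F)(F)F)cc2)s1` gives 3.85 ug/mL
- compound 2 `CN(C(=O)NC(=O)c1ccc(F)c(F)c1)c1nc(C(F)(F)F)c(C(=O)N/N=C/c2ccc([N+](=O)[O-])cc2)s1` gives 2.99 ug/mL

Among the compounds with values here, compound 1 holds the highest of the two numbers in this assay, and its only neighbour is compound 2; the step of a 1.3-fold lower number from compound 1 to compound 2 (0.11 log units; within the scatter) lies within the scatter, so the two cannot be ordered.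

Compound 3 `CN(C(=O)NC(=O)c1c(F)cccc1F)c1nc(C(F)(F)F)c(C(=O)N/N=C/c2ccc(C(F)(F)F)cc2)s1` is not yet measured. It is built from compound 1 by 2,6-difluorophenyl in place of 3,4-difluorophenyl on a carbonyl carbon. Within the data shown here, no measured step touches this part of the molecule: the single step seen, from compound 1 to compound 2, concerns the aryl on the hydrazone and was within the scatter. There is therefore nothing to point to a change in either direction, and the working expectation for compound 3 is a number close to that of compound 1, with the step of a 1.0-fold higher number from compound 1 to compound 3 (0.02 log units; within the scatter) expected to stay within the scatter. Compound 3 is estimated at 4 ug/mL, with a range from 1.5 ug/mL to 11 ug/mL that reflects the absence of any comparable precedent.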

Compound 3, half-maximal inhibitory concentration: 34.9 ug/mL
Compound 3: the middle estimate sits 8.7-fold (0.94 log units) below what was measured; measured number outside the range, above it.
By their numbers in this assay, from the lowest: compounds 2 and 1 (each within the scatter of the next); then compound 3.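

In this assay, the aryl on the carbonyl carbon emerges as a sensitive part of the series: 2,6-difluorophenyl in place of 3,4-difluorophenyl gives a 9.1-fold higher number from compound 1 to compound 3 (0.96 log units; beyond the scatter), which means weaker inhibition. Within the data shown here, the two groups have the same atoms and differ only in how these are joined, so the arrangement of the two fluorines on this ring matters, whereas the one earlier step, at the hydrazone aryl, stayed within the scatter. No available measurement accounts for this loss of inhibition.

Going by these compounds, it remains open whether plain phenyl or a pyridine ring on this carbonyl carbon would track with compound 1 or compound 3. On these data alone, it is also open whether the same change has a comparable effect when nitro replaces trifluoromethyl on the hydrazone aryl.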